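The source may hold more compounds than are shown below. What is called first, only, known or untested is meant among the compounds shown, and "the series" means these compounds.

Measured in a functional assay on MCF7 cells (Homo sapiens) for inhibition, read by MTT assay, with a stated time of 72 h; on this read-out higher numbers stand for weaker inhibition and lower numbers for stronger inhibition:
- Compound 1 `COc1cc(OC)c(OC)cc1/C=C/C(=O)c1ccc(Cl)cc1`: 29500 nM
- Compound 2 `COc1ccc(C(=O)/C=C/c2cc(OC)c(OC)cc2OC)cc1`: 33900 nM

These two numbers sit within the usual scatter of each other, so compound 2 cannot be separated from compound 1, and both belong to the same level in this assay.

The next compound to consider is compound 3 `COc1cc(OC)c(OC)cc1/C=C/C(=O)c1ccccc1`. It has hydrogen in place of methoxy on an aromatic carbon, so a 4-methoxyphenyl becomes a phenyl (hydrogen in place of methoxy on an aromatic carbon).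

Among the measured compounds shown here, only one measured step bears on this change, and it concerns the same aromatic carbon: a 1.1-fold higher number from compound 1 to compound 2 (0.06 log units; within the scatter). Swapping methoxy for chloro there made no difference beyond the scatter. For the measured compounds named here, no measured compound yet carries hydrogen on that carbon, so this evidence is thin and the range must stay generous. Even so, with only that small step as a guide, no shift beyond the scatter is expected in this assay.

The expected step is a 1.1-fold lower number from compound 2 to compound 3 (0.05 log units; within the scatter). Compound 3 is therefore estimated at 30000 nM, with an expected range from 14000 nM to 65000 nM.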

Compound 3, half-maximal inhibitory concentration: > 150000 nM
Compound 3: a limit, no number; the forecaster's own chance of this, stated with the estimate: 10%; middle value at least 5.0-fold (0.69 log units) away from the limit.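

In this assay, going by these compounds, compound 3 gives only a limit (> 150000 nM) and not a number, so the true size of its steps remains unknown. Even so, the position para to a large group proves sensitive to losing its substituent: hydrogen in place of methoxy gives an at least 4.4-fold higher number from compound 2 to compound 3 (0.64 log units; beyond the scatter) and hydrogen in place of chloro gives an at least 5.0-fold higher number from compound 1 to compound 3 (0.70 log units; beyond the scatter), and on this read-out a higher number means weaker inhibition. The earlier pair could not show this, since methoxy and chloro could not be separated (a 1.1-fold higher number from compound 1 to compound 2 (0.06 log units; within the scatter)), which made the position look indifferent, whereas these three compounds show that having either group there gives stronger inhibition than having hydrogen.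

On these data alone, what remains open is whether the need is for these two groups in particular or for almost any group on this carbon, a question that an amine, a fluorine or a longer chain such as ethoxy at the same place could help to answer. As far as these compounds go, it is also open whether the same loss would appear with a different set of methoxy groups on the other ring of the shared core.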